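Extending the chain on the core nitrogen of compound 1

A few compounds are considered here, and "the series" means these few. Any claim that something is new, unique, unknown or untested is made for them only; others in the source may bear on it.

Measured so far:
Compound 1, `Cn1nc(-c2cccnc2)c2ccccc2c1=O`: 11500 nM
Compound 2, `C=CCn1nc(-c2cccnc2)c2ccccc2c1=O`: 2140 nM
Compound 3, `O=c1c2ccccc2c(-c2cccnc2)nn1Cc1cccc(Cl)c1`: 4170 nM

In a functional assay (trachea) with Cavia porcellus as the target (on this read-out higher numbers stand for weaker inhibition and lower numbers for stronger inhibition), compound 1 gives the highest of the three numbers; compound 3 lies nearest and compound 2 furthest. Compound 4, `CC(C)NC(=O)CCCn1nc(-c2cccnc2)c2ccccc2c1=O`, is not yet measured. It differs from compound 1 by 2-(isopropylcarbamoyl)ethyl in place of hydrogen on a saturated chain carbon bound to an aromatic nitrogen. Among the measured compounds shown here, two measured steps bear on this: a 5.4-fold lower number from compound 1 to compound 2 (0.73 log units; beyond the scatter) and a 2.8-fold lower number from compound 1 to compound 3 (0.44 log units; beyond the scatter), both modest and both lowering the number when the hydrogen is replaced. For the measured compounds named here, the new group is larger and carries a donor and an acceptor, which no measured step covers. A modest lowering is therefore expected, a 2.6-fold lower number from compound 1 to compound 4 (0.41 log units; beyond the scatter), and compound 4 is estimated at 4500 nM (range 1500 nM to 12000 nM).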

Compound 4, half-maximal inhibitory concentration: 64600 nM
The estimate for compound 4 lay 14-fold (1.16 log units) below the measured number; the measured number lies above the stated range.
By their numbers in this assay, from the lowest: compounds 2 and 3 (each within the scatter of the next); then compound 1; then compound 4.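

In this assay, replacing hydrogen at this place does not always lower the number: 2-(isopropylcarbamoyl)ethyl gives a 5.6-fold higher number from compound 1 to compound 4 (0.75 log units; beyond the scatter) and so runs opposite to the vinyl and 3-chlorophenyl steps. Measured against those groups, the change is larger, with a 15-fold higher number from compound 3 to compound 4 (1.19 log units; beyond the scatter) and a 30-fold higher number from compound 2 to compound 4 (1.48 log units; beyond the scatter) showing that the entering group sets both direction and size here. Nothing available gives a reason for this reversal. Whether the chain or its amide end accounts for the higher number stays open, and a plain butyl chain, or a chain ending in an amine or a carboxylic acid, would help separate the two.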